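Removing the tert-butyl group from compound 2

This account rests on a few compounds, and the source may have more. Where it says the series, first, only, none or still open, it means among the compounds named here.

Measured in a functional assay on HepG2 cells (Homo sapiens) for inhibition, read by MTT assay, with a stated time of 72 h; a lower number here means a stronger inhibitor, a higher number a weaker inhibitor:
- compound 1 `Cc1ccc(-c2nnc(SCCCN3CCN(c4nc5ccccc5o4)CC3)o2)cc1` gives 154000 nM
- compound 2 `CC(C)(C)Oc1ccc(-c2nnc(SCCCN3CCN(c4nc5ccccc5o4)CC3)o2)cc1` gives 121000 nM

Going by the values given here, compound 2 sits within the scatter of compound 1 in this assay, so the two numbers set no order between these compounds and compound 2 stands level with its only measured neighbour.

The next compound is compound 3 `Oc1ccc(-c2nnc(SCCCN3CCN(c4nc5ccccc5o4)CC3)o2)cc1`, which has hydrogen in place of tert-butyl on an oxygen on an aromatic ring, taking tert-butoxy to hydroxy (hydrogen in place of tert-butyl on an oxygen on an aromatic ring).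

Among the compounds with values here, one measured step bears on this change: a 1.3-fold lower number from compound 1 to compound 2 (0.10 log units; within the scatter) for tert-butoxy in place of methyl on an aromatic carbon. That step stays within the scatter, so exchanging methyl for tert-butoxy left the number in this assay unresolved. Within the data shown here, it is only indirect evidence, as no measured compound yet carries hydroxy. With nothing pointing either way, no step beyond the scatter is expected, and the expected step is a 1.0-fold lower number from compound 2 to compound 3 (0.00 log units; within the scatter) in this assay with no favoured direction.

The estimate for compound 3 is 120000 nM with an expected range from 55000 nM to 250000 nM in this assay.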

Compound 3, half-maximal inhibitory concentration: 502000 nM
Compound 3: the middle estimate sits 4.2-fold (0.62 log units) below what was measured; measured number outside the range, above it.
By their numbers in this assay, from the lowest: compounds 2 and 1 (each within the scatter of the next); then compound 3.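

Working notes on the ring substituent: in this assay this place on the aromatic ring does respond to the group it carries, since hydroxy gives a 4.1-fold higher number from compound 2 to compound 3 (0.62 log units; beyond the scatter) and also a 3.3-fold higher number from compound 1 to compound 3 (0.51 log units; beyond the scatter), while methyl and tert-butoxy remain unresolved at a 1.3-fold lower number from compound 1 to compound 2 (0.10 log units; within the scatter). Both steps run the same way, so among these three groups hydroxy alone stands apart, as the weakest inhibitor of the set. Compound 2 and compound 3 both carry an oxygen on the aromatic ring, so that oxygen alone does not go with the higher number, and the separation appears only when hydrogen replaces tert-butyl on it; no measurement at hand accounts for this shift.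

Open, on these data alone, is whether the higher number is particular to hydroxy, or whether methoxy, an amine or a carboxylic acid at this place would read the same way. Also open, as far as these compounds go, is whether a longer chain in place of tert-butyl on this oxygen would stay level with compound 2 or move towards compound 3.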